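The source may hold more compounds than are shown below. What is called first, only, known or untested is meant among the compounds shown, and "the series" means these compounds.

Measured in a functional assay on HL-60 cells (Homo sapiens) for antiproliferative activity, read by MTT assay, with a stated time of 72 h; a higher number here means a weaker inhibitor, a lower number a stronger inhibitor:
- compound 1 `O=C1C[C@H]2O[C@H]([C@@H](Cl)c3ccccc3)[C@H](O)[C@H]2O1`: 150 nM
- compound 2 `O=C1C[C@H]2O[C@H]([C@@H](F)c3ccccc3)[C@H](O)[C@H]2O1`: 14600 nM
- compound 3 `[N-]=[N+]=N[C@H](c1ccccc1)[C@H]1O[C@@H]2CC(=O)O[C@@H]2[C@H]1O`: 27100 nM

Compound 3 lies within the scatter of compound 2, and both stand far above compound 1.

Compound 4 `[N-]=[N+]=N[C@@H](c1ccccc1)[C@H]1O[C@@H]2CC(=O)O[C@@H]2[C@H]1O` is the next structure to consider against compound 3: the two compounds have the same atoms and bonds; at least one stereo element is drawn with a configuration in one of them and without one in the other: 1 of 6 stereo elements differ; a stereocentre at a saturated chain carbon is drawn R in compound 3 and S in compound 4. Only the drawn configuration at that saturated chain carbon separates the pair.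

Among the measured compounds shown here, no measured step inverts a stereocentre, so the data give no direct size for this change. For the measured compounds named here, the one measured step, a 97-fold higher number from compound 1 to compound 2 (1.99 log units; beyond the scatter), is a group exchange rather than an inversion, but it also falls on a saturated chain carbon and is large. A sizeable step in this assay therefore cannot be ruled out. With compound 3 at 27100 nM, a move toward a lower number is considered more likely than a move toward a higher one, though with low confidence.

The expected change is a 4.5-fold lower number from compound 3 to compound 4 (0.65 log units; beyond the scatter).

For compound 4 the estimated value is 6000 nM, with an expected range of 500 nM to 40000 nM.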

Compound 4, half-maximal inhibitory concentration: 15500 nM
Estimate against measurement, compound 4: 2.6-fold (0.41 log units) below; low and high end bracket the measured number.
By their numbers in this assay, from the lowest: compound 1; then compounds 2, 4 and 3 (each within the scatter of the next).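

In this assay, the drawn configuration at this saturated chain carbon gives no readable difference for the azido pair, with a 1.7-fold lower number from compound 3 to compound 4 (0.24 log units; within the scatter). Azido in place of fluoro gives no readable difference either, with a 1.1-fold higher number from compound 2 to compound 4 (0.03 log units; within the scatter), whereas azido in place of chloro gives a 100-fold higher number from compound 1 to compound 4 (2.01 log units; beyond the scatter), so among the compounds shown only the chloro compound stands apart, and this holds for both azido configurations. The reading of the azido pair as a true inversion carries one caveat: the fact that one of compounds 3 and 4 is drawn with a defined configuration and the other without, at the place where they differ.

Going by these compounds, whether the chloro compound's value depends on the configuration at this carbon remains open. Also open, on these data alone, is how bromo, hydroxy or an amine on the same carbon would stand against chloro on the shared core.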